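This account rests on a few compounds, and the source may have more. Where it says the series, first, only, none or still open, it means among the compounds named here.

The measured compounds, each with its result in a functional assay on DU-145 cells (Homo sapiens) for inhibition, read by trypan blue exclusion, with a stated time of 96 h; a higher number here means a weaker inhibitor of growth, a lower number a stronger inhibitor of growth:
- compound 1 `Cc1ccc(S(=O)(=O)/C(=C/c2ccc(C)s2)C(=O)c2ccc(Br)cc2)cc1`, which gives 25000 nM
- compound 2 `COc1ccccc1/C=C(\C(=O)c1ccc(Br)cc1)S(=O)(=O)c1ccc(C)cc1`, which gives 1000 nM
- compound 3 `COc1ccccc1/C=C(/Sc1ccc(C)cc1)C(=O)c1ccc(Br)cc1`, which gives 9000 nM

Compound 4 `Cc1ccc(S/C(=C/c2ccc(C)s2)C(=O)c2ccc(Br)cc2)cc1` has not yet been measured in this assay.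

Compounds 1 and 2 share a core and differ in one place: 5-methylthiophen-2-yl in place of 2-methoxyphenyl on a double-bonded chain carbon bound to a double-bonded chain carbon. Among the measured compounds shown here, this single swap made a large step, a 25-fold higher number from compound 2 to compound 1 (1.40 log units; beyond the scatter), so the compound carrying the 5-methylthiophen-2-yl group was a far weaker inhibitor of growth than the one carrying the 2-methoxyphenyl group.

Compound 3 has a different core from compound 2, and the difference between the two cores is not broken down here. Compound 3 itself sits with the second highest of the three numbers, a weaker inhibitor of growth than compound 2 and a stronger one than compound 1.

From compound 3 to compound 4 the same change is made: 5-methylthiophen-2-yl in place of 2-methoxyphenyl on a double-bonded chain carbon bound to a double-bonded chain carbon. For the measured compounds named here, because the same change in the same place gave a 25-fold higher number from compound 2 to compound 1 (1.40 log units; beyond the scatter), the step from compound 3 to compound 4 is expected to be of a similar size, that is, a 17-fold higher number from compound 3 to compound 4 (1.22 log units; beyond the scatter), although only one earlier example is available to rest this on. Compound 4 is therefore expected to be a weak inhibitor of growth in this assay, with an estimated value of 150000 nM, most likely between 40000 nM and 500000 nM.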

Compound 4, concentration for 50% growth inhibition: > 100000 nM
Compound 4: a limit, no number (the forecaster's own chance of this, stated with the estimate: 35%); the middle value is on the limit's open side.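

In this assay compound 4 gives > 100000 nM, which is a limit of the assay and not a number. Putting 5-methylthiophen-2-yl in place of 2-methoxyphenyl therefore weakened growth inhibition on the second core as well, with an at least 11-fold higher number from compound 3 to compound 4 (1.04 log units; beyond the scatter), so the direction of the change carried over in this one pair of cores. This does not show that the change costs the same amount on both cores, and two cores are too few to support a general rule for the series: the same change on two cores in this assay, a 25-fold higher number (1.40 log units; beyond the scatter) from compound 2 to compound 1 and an at least 11-fold higher number (1.04 log units; beyond the scatter) from compound 3 to compound 4; the limit leaves it open whether they differ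

The compounds shown leave open whether the loss comes from removing the 2-methoxyphenyl group or from introducing the 5-methylthiophen-2-yl group, and a plain phenyl or an unsubstituted thiophen-2-yl in the same place would help to separate these two readings. On these data alone, it also remains open how other groups in that place, such as a 2-hydroxyphenyl or a phenyl ring carrying an amine or a carboxylic acid, would compare with the 2-methoxyphenyl group on either core.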